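This account rests on a few compounds, and the source may have more. Where it says the series, first, only, none or still open, it means among the compounds named here.

Measured so far in a functional assay on U-251 cells (Homo sapiens) for antiproliferative activity, read by MTT assay, with a stated time of 48 h; on this read-out higher numbers stand for weaker inhibition and lower numbers for stronger inhibition:
- compound 1 `COc1cc(-c2cccc3nc(-c4cccc(Cl)c4)oc23)cc(OC)c1OC` gives 18500 nM
- compound 2 `COc1cc(-c2cccc3nc(-c4ccc(Cl)cc4)oc23)cc(OC)c1OC` gives 1600 nM

Compound 2 holds the lower of the two numbers, and so the stronger inhibition of the pair. Going by the values given here, the only measured step is a 12-fold lower number from compound 1 to compound 2 (1.06 log units; beyond the scatter), a large one, exchanging 3-chlorophenyl for 4-chlorophenyl.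

The next compound is compound 3 `COc1cc(-c2cccc3nc(-c4cccc(O)c4)oc23)cc(OC)c1OC`, with 3-hydroxyphenyl in place of 4-chlorophenyl on an aromatic carbon. The measured step bears on this change only in part. Compound 3 carries a 3-substituted phenyl group by name, as does compound 1, whose value of 18500 nM is the higher one. Among the compounds with values here, no measured compound carries a hydroxyl group, so the effect of that exchange remains open. In this assay a move to a higher number is therefore expected, probably somewhat smaller than the measured step and beyond the scatter. The expected step is a 4.4-fold higher number from compound 2 to compound 3 (0.64 log units; beyond the scatter). The estimated value for compound 3 is 7000 nM, with an expected range from 1800 nM to 28000 nM.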

Compound 3, half-maximal inhibitory concentration: 5500 nM
The estimate for compound 3 lay 1.3-fold (0.10 log units) above the measured number; low and high end bracket the measured number.
By their numbers in this assay, from the lowest: compound 2; then compound 3; then compound 1.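

In this assay, the 3-substituted phenyl group now has two measured forms, and a 3.4-fold lower number from compound 1 to compound 3 (0.53 log units; beyond the scatter) shows that hydroxy in place of chloro on this ring gives a modest gain, beyond the scatter. The 4-chlorophenyl group of compound 2 still keeps the lowest number of the three, with a 3.4-fold higher number from compound 2 to compound 3 (0.54 log units; beyond the scatter), so the hydroxy group recovers only part of the loss seen with 3-chlorophenyl. That step exchanges both the substituent and its place on the phenyl ring, so it cannot be divided between the two changes, while the compound 1 comparison isolates the substituent and the earlier chlorine comparison isolates its place. No measurement at hand accounts for either difference.

The compounds shown leave open whether hydroxy would also improve on chloro in a 4-substituted phenyl group, as 4-hydroxyphenyl would test against compound 2. They also leave open how other groups on this phenyl ring, such as an amine, a methoxy group or a carboxylic acid, would compare with the hydroxy group of compound 3 and the chloro group of compound 2.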